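Series notes: methyl replacing pyrimidin-2-yl on the ring amine nitrogen

A few compounds are considered here, and "the series" means these few. Any claim that something is new, unique, unknown or untested is made for them only; others in the source may bear on it.

Measured compounds:
compound 1 `Nc1ccccc1NC(=O)c1ccc(CSC(=S)N2CCN(C3CCCCC3)CC2)cc1` — 75.3%
compound 2 `Nc1ccccc1NC(=O)c1ccc(CSC(=S)N2CCc3cc(Cl)ccc32)cc1` — 82.2%
compound 3 `Nc1ccccc1NC(=O)c1ccc(CSC(=S)N2CCN(c3ncccn3)CC2)cc1` — 64.8%

All three numbers come from a functional assay on MGC-803 cells (Homo sapiens) for antiproliferative activity, read by CCK-8 assay, with a stated time of 72 h, tested at 8 uM; a lower number here means a weaker effect, a higher number a stronger effect of the compound at the concentration tested. Compound 3 stands lowest of the three; compound 1 is the nearest to it and compound 2 the furthest, both gaps beyond the scatter. Among the measured compounds shown here, only one pair differs in a single place: a number 10.5 percentage points lower from compound 1 to compound 3 (beyond the scatter), a modest step.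

Compound 4 `CN1CCN(C(=S)SCc2ccc(C(=O)Nc3ccccc3N)cc2)CC1` is the next member. It differs from compound 3 as follows: methyl in place of pyrimidin-2-yl on an amine nitrogen in a ring

For the measured compounds named here, no measured pair exchanges a ring group for methyl at this nitrogen, so the only step that bears on the change is the one from compound 1 to compound 3, which shows that the group on this nitrogen moves the number by a modest amount. Compound 2 carries a different ring system here and gives no guidance on this exchange. For compound 4 a step upward of roughly that size is expected, a number 6.2 percentage points higher from compound 3 to compound 4 (within the scatter), because the group on this nitrogen already moved the number by a number 10.5 percentage points lower from compound 1 to compound 3 (beyond the scatter). Compound 4 is therefore estimated at 71%, in the range 57% to 83%.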

Compound 4, a percentage reported as inhibition, at one concentration (the size of the read-out at that concentration, not a potency): 84.4%
Compound 4: the middle estimate sits 13.4 percentage points below what was measured, and the stated range ends below it.
By their numbers in this assay, from the lowest: compound 3; then compounds 1, 2 and 4 (each within the scatter of the next).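

In this assay, the exchange on this ring amine nitrogen gives a number 19.6 percentage points higher from compound 3 to compound 4 (beyond the scatter), so a methyl group here does not carry the lower number seen with pyrimidin-2-yl. Methyl in place of cyclohexyl gives a number 9.1 percentage points higher from compound 1 to compound 4 (within the scatter), so among the groups shown a ring on this nitrogen is not needed to hold the number, and only the pyrimidin-2-yl compound stands apart from the other two. On the thiocarbonyl carbon, 4-methylpiperazin-1-yl in place of 5-chloro-2,3-dihydro-1H-indol-1-yl gives a number 2.2 percentage points higher from compound 2 to compound 4 (within the scatter), so these two groups cannot be told apart at this single concentration.

Nothing available bears on why pyrimidin-2-yl stands apart. Open, as far as these compounds go, is how a hydrogen, an ethyl, a phenyl or a 2-hydroxyethyl group on this nitrogen would compare with methyl.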